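Swapping an aminophenyl for a methoxypyridyl on the core

The source may hold more compounds than are shown below. What is called first, only, known or untested is meant among the compounds shown, and "the series" means these compounds.

Measured so far:
compound 1 `CCO/N=C/c1ccc(OCCC(C)CCN2CCN(c3ccnc(OC)c3)C2=O)cc1` — > 100000 nM
compound 2 `CC(CCOc1ccc(-c2noc(C(C)(C)C)n2)cc1)CCN1CCN(c2ccnc(N)c2)C1=O` — 55000 nM

Both compounds share a core and were tested in an ADME assay on RD cells (Homo sapiens) for cytotoxicity, read by MTT assay, with a stated time of 24 h; on this read-out higher numbers stand for lower toxicity in this test and lower numbers for higher toxicity in this test. Compound 1 gives > 100000 nM in this assay, which is a limit of the test and not a number. Compound 2 gives 55000 nM in this assay. The two compounds differ in more than one place, so no single step can be read between them; they simply show where each stands.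

Compound 3 `CCO/N=C/c1ccc(OCCC(C)CCN2CCN(c3cccc(N)c3)C2=O)cc1` has not yet been measured. It differs from compound 1 in one place only: 3-aminophenyl in place of 2-methoxypyridin-4-yl on an amide-type nitrogen in a ring. Among the measured compounds shown here, no measured pair with this same change exists, so its effect is open. The expectation is a step of no more than the usual scatter in either direction, since compound 1 already sits at the limit of > 100000 nM in this assay, at which 1 of the 2 values shown sits, and compound 2 is not far below. Compound 3 is therefore expected at about 80000 nM in this assay, within a range from 30000 nM to 200000 nM, which would mean an expected step of an at least 1.2-fold lower number from compound 1 to compound 3 (0.09 log units; that floor lies within the scatter).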

Compound 3, half-maximal cytotoxic concentration: > 100000 nM
Compound 3 ended at the assay's limit; the forecaster's own chance of this, stated with the estimate: 50%; at least 1.2-fold (0.09 log units) between middle value and limit.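

No step can be read from compound 1 to compound 3, because both compounds sit at a limit of the test and neither gives a number: the limit of > 100000 nM in this assay, at which 2 of the 3 values shown sit.

The compounds shown leave open whether 3-aminophenyl in place of 2-methoxypyridin-4-yl on the shared core changes the cytotoxicity read-out at all, and in which direction.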